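The compounds below may be only part of what the source reports. "The series", "measured", "known", "first", "only" and "open" are said of these compounds alone.

Series so far, in a functional assay on Jurkat cells (Homo sapiens) for cytotoxicity, with a stated time of 72 h; a lower number here means that less compound is needed, a higher number that more compound is needed for the effect:

compound 1 `C=C[C@@](C)(/C=C/c1ccc(O)c(/C=C/C#N)c1)CCC=C(C)C` gives > 49000 nM
compound 2 `C=C[C@@](C)(/C=C/c1ccc(O)c(/C=C/C(=O)OCC)c1)CCC=C(C)C` gives > 49000 nM
compound 3 `C=C[C@@](C)(/C=C/c1ccc(O)c(/C=C/c2ccc(F)cc2)c1)CCC=C(C)C` gives > 49000 nM

Each of these entries is a limit and not a number. Compound 3 stands at > 49000 nM, which is a limit of this assay. The series as a whole sits at the limit of > 49000 nM in this assay, at which 3 of the 3 values shown sit, so no order among the three compounds can be read.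

Next is compound 4 `C=C[C@@](C)(/C=C/c1ccc(O)c(/C=C/c2ccc(Cl)cc2)c1)CCC=C(C)C`. The change is chloro in place of fluoro on an aromatic carbon, para to a large group.

The nearest measured evidence comes from changes on the same chain carbon: a step that the two limits leave unreadable from compound 1 to compound 3, a step that the two limits leave unreadable from compound 2 to compound 3 and a step that the two limits leave unreadable from compound 1 to compound 2. None of these swaps one halogen for another, and none has a readable size. No size or direction of change in this assay can therefore be derived from them. The expectation for compound 4 stays with compound 3 at > 49000 nM, and another limit is the likeliest report.

The expected step is a number no higher from compound 3 to compound 4 (the limit leaves the size open), with no direction favoured. The estimate for compound 4 is 49000 nM, with an expected range of 22000 nM to 100000 nM.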

Compound 4, half-maximal effective concentration: > 49000 nM
Compound 4 was reported as a limit; the forecaster's own chance of this, stated with the estimate: 80%; the middle value sits exactly at the limit.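

In this assay compound 4 gives > 49000 nM, which is a limit and not a number. For the compounds shown here, no step linking compound 4 to compound 1, compound 2 or compound 3 can be read. The compounds shown leave open how the series would order and what any of its changes does to the read-out, as every entry is a limit: the limit of > 49000 nM in this assay, at which 4 of the 4 values shown sit.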